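The source may report more compounds than this note shows. Statements on the series, on what has been measured and on what is new or still open speak of the compounds shown alone.

Measured in an assay on HeLa cells for displacement of a labelled ligand from 5-hydroxytryptamine receptor 6 (Homo sapiens); on this read-out lower numbers stand for stronger inhibition and higher numbers for weaker inhibition:

compound 1 `CN1CCCC(n2cc(S(=O)(=O)c3ccc(Cl)cc3)c3cccnc32)C1`: 11.5 nM
compound 2 `CCN1CCCC(n2cc(S(=O)(=O)c3ccc(Cl)cc3)c3cccnc32)C1`: 33.5 nM
compound 3 `CCN1CCCC(n2cc(S(=O)(=O)c3cccc(F)c3)c3cccnc32)C1`: 4.4 nM

Compound 1 and compound 2 differ by one change, (methyl in place of hydrogen on a saturated chain carbon bound to an amine nitrogen in a ring), and the result in this assay is a 2.9-fold higher number from compound 1 to compound 2 (0.46 log units; beyond the scatter). Compound 2 and compound 3 differ elsewhere, a 7.6-fold lower number from compound 2 to compound 3 (0.88 log units; beyond the scatter). How the core of compound 1 differs from the core of compound 3 is not broken down here. Compound 4 `CC(C)N1CCCC(n2cc(S(=O)(=O)c3cccc(F)c3)c3cccnc32)C1` carries the same kind of change as the step from compound 1 to compound 2, (methyl in place of hydrogen on a saturated chain carbon bound to an amine nitrogen in a ring and a saturated chain carbon); here the carbon that receives the methyl is also bound to a saturated chain carbon. A step of similar size, weakening binding, is expected to repeat because the same kind of change from compound 1 to compound 2 gave a 2.9-fold higher number from compound 1 to compound 2 (0.46 log units; beyond the scatter). For compound 4 the estimated step is therefore a 2.5-fold higher number from compound 3 to compound 4 (0.40 log units; beyond the scatter). Compound 4 is therefore expected to give about 11 nM in this assay, likely between 4.5 nM and 30 nM.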

Compound 4, inhibition constant: 3.4 nM
Compound 4: middle estimate off by 3.2-fold (0.51 log units), on the high side; the measured number lies below the stated range.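

In this assay, the extra methyl that turns ethyl into isopropyl gives a 1.3-fold lower number from compound 3 to compound 4 (0.11 log units; within the scatter), a step too small to read as a real change in binding. The same kind of change therefore did not carry over at the same size from one core to the other: the same change on two cores in this assay, a 2.9-fold higher number (0.46 log units; beyond the scatter) from compound 1 to compound 2 and a 1.3-fold lower number (0.11 log units; within the scatter) from compound 3 to compound 4, 3.8-fold (0.58 log units) apart, beyond the scatter of two such steps

This does not show why the two steps differ, as the pairs differ both in the group on the sulfonyl sulfur and in the chain that receives the methyl, and two pairs cannot separate these.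

The compounds shown leave open how the ethyl to isopropyl change behaves with 4-chlorophenyl on the sulfonyl sulfur. They also leave open how a longer chain, such as propyl, would fare on the ring amine nitrogen.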